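Adding a phenyl to compound 2

The source may report more compounds than this note shows. Statements on the series, on what has been measured and on what is new or still open speak of the compounds shown alone.

compound 1 `CN(C)CCCn1nc(C2=C(c3cn(C)c4ccccc34)C(=O)N(c3ccccc3)C2=O)c2cccnc21`: 31200 nM
compound 2 `Cn1cc(C2=C(c3nn(CCCCn4ccnc4)c4ncccc34)C(=O)NC2=O)c2ccccc21`: 29200 nM

Both values come from a functional assay on SMMC-7721 cells (Homo sapiens) for antiproliferative activity, read by MTT assay, with a stated time of 48 h; on this read-out higher numbers stand for weaker inhibition and lower numbers for stronger inhibition. Going by the values given here, compound 1 and compound 2 lie within the usual scatter of each other, so compound 2 cannot be ranked against the only other measured compound. Neither value signals strong inhibition of these cells on its own terms.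

The next compound, compound 3 `Cn1cc(C2=C(c3nn(CCCCn4ccnc4)c4ncccc34)C(=O)N(c3ccccc3)C2=O)c2ccccc21`, keeps everything in compound 2 except one spot: phenyl in place of hydrogen on an amide-type nitrogen in a ring. Among the compounds with values here, no pair of measured compounds differs in one place only, so this change has no direct precedent here. The nearest hint is indirect. Compound 1, with a phenyl on that nitrogen, gives 31200 nM, and compound 2, without one, gives 29200 nM. That hint is weak, yet it offers no reason to expect a large shift in either direction, so no change beyond the scatter is expected. The expected result is a 1.1-fold lower number from compound 2 to compound 3 (0.03 log units; within the scatter). For compound 3 the estimated value is 27000 nM, with an expected range from 9000 nM to 80000 nM.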

Compound 3, half-maximal inhibitory concentration: 1760 nM
Compound 3: middle estimate off by 15-fold (1.19 log units), on the high side, outside the stated range (below it).
By their numbers in this assay, from the lowest: compound 3; then compounds 2 and 1 (each within the scatter of the next).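

In this assay, the amide-type nitrogen in the five-membered ring proves to be a sensitive position, since phenyl in place of hydrogen there gives a 17-fold lower number from compound 2 to compound 3 (1.22 log units; beyond the scatter). The phenyl is not enough on its own, though: compound 1 carries it too, and with the phenyl kept, (1H-imidazol-1-yl)methyl in place of dimethylamino on a saturated chain carbon, three bonds along the chain from an aromatic nitrogen, gives an 18-fold lower number from compound 1 to compound 3 (1.25 log units; beyond the scatter), so among these three compounds the low number appears only where the phenyl and the imidazole-bearing chain occur together, with compound 1 and compound 2 each holding just one of the two. No measurement shown here explains why either change matters or why the two work only in combination.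

From the compounds shown here alone, it remains open whether the gain needs a phenyl in particular, or whether a methyl or a benzyl on the same nitrogen would serve as well. Going by these compounds, it is also open how far the imidazole-bearing chain can change, for instance by becoming shorter or by ending in a morpholine, before the low number is lost.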